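A few compounds are considered here, and "the series" means these few. Any claim that something is new, unique, unknown or untested is made for them only; others in the source may bear on it.

Compound 1 `C=C[C@@](C)(/C=C/c1ccc(OS(=O)(=O)C(F)(F)F)cc1)CCC=C(C)C`: > 26000 nM
Compound 2 `C=C[C@@](C)(/C=C/c1ccc(Nc2ccccc2)cc1)CCC=C(C)C`: > 26000 nM
Compound 3 `C=C[C@@](C)(/C=C/c1ccc(Nc2ccc(OC(F)(F)F)cc2)cc1)CCC=C(C)C`: > 26000 nM

All three entries come from a functional assay on Raji cells (Homo sapiens) for cytotoxicity, with a stated time of 72 h; on this read-out lower numbers stand for an effect already at smaller amounts and higher numbers for an effect only at larger amounts of compound. Compound 3 gives > 26000 nM, which is a limit of the assay and not a number. It has no readable place in an order, since the whole series stands at the limit of > 26000 nM in this assay, at which 3 of the 3 values shown sit.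

Compound 4 `C=C[C@@](C)(/C=C/c1ccc(Nc2ccc(F)cc2)cc1)CCC=C(C)C` keeps the core of compound 3 and changes one group: fluoro in place of trifluoromethoxy on an aromatic carbon, para to a large group (fluoro in place of trifluoromethoxy on an aromatic carbon).

Among the measured compounds shown here, two measured steps bear on this change. The closer one is a step that the two limits leave unreadable from compound 2 to compound 3, where trifluoromethoxy came in place of hydrogen on an aromatic carbon. The other is a step that the two limits leave unreadable from compound 1 to compound 2, where anilino came in place of ((trifluoromethyl)sulfonyl)oxy. For the measured compounds named here, neither step has a size that can be carried over, and no compound here has yet given a real number.

Compound 4 is therefore expected to stay near the limit in this assay, given that compound 3 sits at the limit of > 26000 nM in this assay, at which 3 of the 3 values shown sit. Going by the values given here, the estimated change is a number no higher from compound 3 to compound 4 (the limit leaves the size open), and no expected step goes beyond the scatter. For compound 4 the expected value is 26000 nM, with an estimated range from 13000 nM to 52000 nM.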

Compound 4, half-maximal effective concentration: > 26000 nM
Compound 4: only a limit was reported; the forecaster's own chance of this, stated with the estimate: 85%; the middle value sits exactly at the limit.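

In this assay compound 4 gives > 26000 nM, which is a limit of the assay and not a number. No step from compound 1, compound 2 or compound 3 to compound 4 can be read, because all four compounds sit at the same limit: the limit of > 26000 nM in this assay, at which 4 of the 4 values shown sit.

The compounds shown leave open whether any of these group changes alters the effect in this assay, and by how much.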